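The compounds below may be only part of what the source reports. "The series", "measured", "known", "first", "only" and "open" are said of these compounds alone.

- Compound 1 `CC1(Nc2ccc(NC(=O)c3cc(Cl)ccc3O)c(Cl)c2)CCCC1`: 157000 nM
- Compound 2 `O=C(Nc1ccc(NC2CCCC2)cc1)c1cc(Cl)ccc1O`: 10000 nM

In an ADME assay on A549 cells (Homo sapiens) for cytotoxicity, read by resazurin assay, with a stated time of 48 h (on this read-out lower numbers stand for higher toxicity in this test and higher numbers for lower toxicity in this test), compound 2 gives the lower of the two numbers at 10000 nM, while compound 1 gives 157000 nM. The gap between these two numbers lies beyond the scatter. Compound 3 `O=C(Nc1ccc(NC2CCCC2)cc1F)c1cc(Cl)ccc1O` differs from compound 2 by fluoro in place of hydrogen on an aromatic carbon. Within the data shown here, no measured pair shows what such a change does, so no shift beyond the scatter is expected in this assay, and the estimated change is a 1.1-fold lower number from compound 2 to compound 3 (0.05 log units; within the scatter). The estimate starts from compound 2 at 10000 nM. Compound 3 is expected at 9000 nM, within an estimated range of 3500 nM to 25000 nM.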

Compound 3, half-maximal cytotoxic concentration: 51000 nM
Estimate against measurement, compound 3: 5.7-fold (0.75 log units) below, and the stated range ends below it.
By their numbers in this assay, from the lowest: compound 2; then compound 3; then compound 1.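

In this assay fluoro in place of hydrogen on this aromatic carbon, ortho to a large group, gives a 5.1-fold higher number from compound 2 to compound 3 (0.71 log units; beyond the scatter) and so moves the read-out beyond the scatter, towards lower toxicity in this test. This is the only change in one place among these compounds, and it shows that a single fluorine at this carbon is enough to shift the number. Going by these compounds, whether a methoxy group or a nitrile on the same carbon would shift it in the same direction stays open. Nothing available gives a reason for the shift.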